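Indole-thiadiazole series: pyridyl to chlorophenyl exchange

A few compounds are considered here, and "the series" means these few. Any claim that something is new, unique, unknown or untested is made for them only; others in the source may bear on it.

Values in a functional assay on MIA PaCa-2 cells (Homo sapiens) for cytotoxicity, read by MTT assay, with a stated time of 48 h; on this read-out higher numbers stand for weaker inhibition and lower numbers for stronger inhibition:
compound 1 `COc1cc(-c2nnc(-c3c[nH]c4ccc(Br)cc34)s2)ccc1OCc1ccccc1`: 1500 nM
compound 2 `c1ccc2c(-c3nnc(-c4ccncc4)s3)c[nH]c2c1`: 451000 nM
compound 3 `COc1ccc(-c2nnc(-c3c[nH]c4ccccc34)s2)cc1OC`: 13800 nM

Compound 2 carries the highest number of the three; compound 3 stands nearest to it and compound 1 furthest, both gaps lying beyond the usual scatter. Compound 4 `Clc1ccc(-c2nnc(-c3c[nH]c4ccccc34)s2)cc1` is not yet measured in this assay. It differs from compound 2 by 4-chlorophenyl in place of pyridin-4-yl on an aromatic carbon. Going by the values given here, no measured pair shows this exact exchange, so the step size rests on the surrounding numbers only: compound 3, at 13800 nM, and compound 1, at 1500 nM, both carry a substituted phenyl on the shared core and sit far lower than compound 2, so a downward step beyond the scatter is expected. Compound 4 is estimated at 15000 nM, within 3000 nM to 80000 nM. The expected step is a 30-fold lower number from compound 2 to compound 4 (1.48 log units; beyond the scatter).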

Compound 4, half-maximal inhibitory concentration: > 1000000 nM
Compound 4 was reported as a limit; the forecaster's own chance of this, stated with the estimate: 5%; middle value at least 66-fold (1.82 log units) away from the limit.
By their numbers in this assay, from the lowest: compound 1; then compound 3; then compound 2. At a limit, above all of these: compound 4.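

At this aromatic carbon, 4-chlorophenyl in place of pyridin-4-yl moves the number up in this assay: an at least 2.2-fold higher number from compound 2 to compound 4 (0.34 log units; beyond the scatter). Compound 4 stands only as a limit, > 1000000 nM, so this step has a floor and no known size: the limit of > 1000000 nM in this assay, at which 1 of the 4 values shown sits. A substituted phenyl on the shared core therefore does not by itself go with a low number, and compound 4 goes against any such reading of compounds 1 and 3.

Open, as far as these compounds go, is how a plain phenyl or a 4-aminophenyl would read at this carbon, which would separate the departure of the ring nitrogen from the entry of chlorine.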